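This account rests on a few compounds, and the source may have more. Where it says the series, first, only, none or still open, it means among the compounds named here.

Compound 2 `NS(=O)(=O)OC[C@@H]1C[C@@H](n2nnc3c(NCCCc4ccccc4)ncnc32)C[C@@H]1O` gives 149 nM in an assay on a protein complex for inhibition of NEDD8 activating enzyme (Homo sapiens), read by HTRF, with a stated time of 2 h, in the presence of a further agent that is not named here (a lower number here means a stronger inhibitor, a higher number a weaker inhibitor), and compound 1 `NS(=O)(=O)OC[C@@H]1C[C@@H](Nc2ncnc(N[C@H]3CCc4ccccc43)c2F)C[C@@H]1O` gives 219 nM, a gap that lies within the usual scatter. Compound 3 `NS(=O)(=O)OC[C@@H]1C[C@@H](n2nnc3c(Nc4n[nH]c5ccccc45)ncnc32)C[C@@H]1O` reaches only a limit of the assay, > 10000 nM. The step of an at least 67-fold higher number from compound 2 to compound 3 (1.82 log units; beyond the scatter) rests on (the limit of > 10000 nM in this assay, at which 1 of the 3 values shown sits). Compound 4 `NS(=O)(=O)OC[C@@H]1C[C@@H](n2nnc3c(Nn4ccc5ccccc54)ncnc32)C[C@@H]1O` differs from compound 2 by 1H-indol-1-yl in place of 3-phenylpropyl on a nitrogen on an aromatic ring. Among the measured compounds shown here, the one measured step that bears on this change, an at least 67-fold higher number from compound 2 to compound 3 (1.82 log units; beyond the scatter), also replaced the 3-phenylpropyl with a group bonded directly to that nitrogen, and it was large and toward weaker inhibition, so a step of similar kind is expected here, toward a higher number. Compound 4 is therefore expected to give about 8000 nM, between 1500 nM and 30000 nM. This estimate means a step of a 54-fold higher number from compound 2 to compound 4 (1.73 log units; beyond the scatter).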

Compound 4, half-maximal inhibitory concentration: > 10000 nM
Compound 4 was reported as a limit (the forecaster's own chance of this, stated with the estimate: 45%); at least 1.2-fold (0.09 log units) between middle value and limit.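

Replacing 3-phenylpropyl with 1H-indol-1-yl on a nitrogen on an aromatic ring leaves the count at 9 heavy atoms, yet it gives an at least 67-fold higher number from compound 2 to compound 4 (1.82 log units; beyond the scatter). The count of heavy atoms alone therefore does not preserve inhibition at this position. Compound 4 is reported only as a limit, and the step between compound 3 and compound 4 cannot be read, so these two groups cannot be ranked: the limit of > 10000 nM in this assay, at which 2 of the 4 values shown sit.

The compounds shown leave open how much of the chain is needed: whether benzyl or 2-phenylethyl on that nitrogen would stay close to compound 2 or fall away like compound 4.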